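Ring-amide substitution in a fused bicyclic series

This account rests on a few compounds, and the source may have more. Where it says the series, first, only, none or still open, it means among the compounds named here.

All numbers below come from a functional assay on HepG2 cells (Homo sapiens) for antiproliferative activity, read by MTT assay, with a stated time of 72 h; on this read-out lower numbers stand for stronger inhibition and higher numbers for weaker inhibition.

Compound 1, `COc1ncc(-c2ccc3c(c2)NC(=O)CO3)cc1NS(=O)(=O)c1ccc(F)cc1`: 6590 nM.
Compound 2, `COc1ncc(-c2ccc3c(c2)N(c2ccc(F)cc2)C(=O)CO3)cc1NS(=O)(=O)c1ccc(F)cc1`: 36400 nM.
Compound 3, `O=C1COc2ccc(-c3cnc4ccccc4c3)cc2N1c1ccc(F)cc1`: 37200 nM.

Compound 2 and compound 1 share one core and differ in a single place: hydrogen in place of 4-fluorophenyl on an amide-type nitrogen in a ring. Within this pair the step is a 5.5-fold lower number from compound 2 to compound 1 (0.74 log units; beyond the scatter), a step that lies beyond the scatter of the read-out. Compound 3 carries a different core; the difference between the core of compound 3 and the core of compound 2 is not broken down here. In this assay the values of compound 3 and compound 2 fall within the scatter of each other, so no order between them is claimed, while compound 1 sits clearly apart from both.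

Compound 4, `O=C1COc2ccc(-c3cnc4ccccc4c3)cc2N1`, has not been measured. It differs from compound 3 as follows: hydrogen in place of 4-fluorophenyl on an amide-type nitrogen in a ring. This is the same change as the one from compound 2 to compound 1, with identical surroundings at the place, and no other pair among the compounds shown carries it. Its size is known from one pair alone, so the expectation rests on a single precedent. Given that compound 2 gives 36400 nM and the step to compound 1 was a 5.5-fold lower number from compound 2 to compound 1 (0.74 log units; beyond the scatter), a comparable step is expected for compound 4, namely a 5.3-fold lower number from compound 3 to compound 4 (0.73 log units; beyond the scatter). As far as these compounds go, whether the change carries over to the second core is untested; the two cores are not compared in any counted way. Within the data shown here, compound 4 is therefore estimated at 7000 nM, with a range from 2500 nM to 22000 nM that allows for the transfer to a new core being weaker or stronger than the one observed step.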

Compound 4, half-maximal inhibitory concentration: 26300 nM
The estimate for compound 4 lay 3.8-fold (0.57 log units) below the measured number; the whole stated range lies below it.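

In this assay, among these compounds, hydrogen in place of 4-fluorophenyl on the amide-type nitrogen in a ring comes with a 1.4-fold lower number from compound 3 to compound 4 (0.15 log units; within the scatter), so on the core of compound 3 this change gives no step that can be told from the scatter. On the core of compound 1, the same change gives a 5.5-fold lower number from compound 2 to compound 1 (0.74 log units; beyond the scatter), and the two steps do not agree in size: the same change on two cores in this assay, a 5.5-fold lower number (0.74 log units; beyond the scatter) from compound 2 to compound 1 and a 1.4-fold lower number (0.15 log units; within the scatter) from compound 3 to compound 4, 3.9-fold (0.59 log units) apart, beyond the scatter of two such steps. With one pair on each core, this shows that the size of the step seen on one core could not be carried over to the other in these four compounds, but it does not show what in the two cores sets the steps apart, or what size the step would take on any further core.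

As far as these compounds go, only hydrogen and 4-fluorophenyl are seen on this nitrogen, so it remains open whether a methyl group, a longer chain, an unsubstituted phenyl or a chain ending in an amine or a carboxylic acid would give steps that differ between the two cores in the same way. A single pair per core also leaves open how much of the gap between the two steps would hold up on repeated measurement in this read-out.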